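The source may report more compounds than this note shows. Statements on the series, on what has been measured and on what is new or still open speak of the compounds shown alone.

Measured compounds:
compound 1, `CCCCOC(=O)N1CCCc2cc(S(=O)(=O)N3CC(c4ccccc4)NC3=O)ccc21`, in a functional assay on COLO 205 cells (Homo sapiens) for antiproliferative activity, read by MTT assay; a higher number here means a weaker inhibitor, a lower number a stronger inhibitor: 4110 nM
compound 2, `O=C(c1ccccc1)N1CCCc2cc(S(=O)(=O)N3CC(c4ccccc4)NC3=O)ccc21`, in this assay: 19300 nM
compound 3, `NC(=O)N1CCCc2cc(S(=O)(=O)N3CC(c4ccccc4)NC3=O)ccc21`, in this assay: > 20000 nM, a limit of the assay and not a number

Compound 1 holds the lowest of the two numbers. Its nearest neighbour is compound 2, with a 4.7-fold higher number from compound 1 to compound 2 (0.67 log units; beyond the scatter). For compound 3 only a limit is known, (the limit of > 20000 nM in this assay, at which 1 of the 3 values shown sits). Compound 4, `O=C(CCl)NC(=O)N1CCCc2cc(S(=O)(=O)N3CC(c4ccccc4)NC3=O)ccc21`, differs from compound 1 at one place: ((chloromethyl)carbonyl)amino in place of butoxy on a carbonyl carbon. For the measured compounds named here, two measured steps bear on this exchange, since each also removes the butoxy from that carbonyl carbon: a 4.7-fold higher number from compound 1 to compound 2 (0.67 log units; beyond the scatter) and an at least 4.8-fold higher number from compound 1 to compound 3 (0.68 log units; beyond the scatter). Both replacements raised the number by a modest amount, and between the two replacement groups themselves there was an at least 1.0-fold higher number from compound 2 to compound 3 (0.01 log units; that floor lies within the scatter). Going by the values given here, nothing among the measured compounds suggests that a third replacement of the butoxy would run the other way, so a rise of similar size is expected, a 3.4-fold higher number from compound 1 to compound 4 (0.53 log units; beyond the scatter). Compound 4 is therefore expected to give about 14000 nM, within 4500 nM to 40000 nM, with a real chance that the assay reports only a limit rather than a number.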

Compound 4, half-maximal inhibitory concentration: 9910 nM
Estimate against measurement, compound 4: 1.4-fold (0.15 log units) above; the range from low to high includes it.
By their numbers in this assay, from the lowest: compound 1; then compounds 4 and 2 (each within the scatter of the next). At a limit, above all of these: compound 3.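

Compound 4 is a third replacement of the butoxy on this carbonyl carbon, and it also gives a higher number: a 2.4-fold higher number from compound 1 to compound 4 (0.38 log units; beyond the scatter). With all three replacements shown, compound 1 keeps the lowest number in this assay, whether the group that enters has a ring, as the phenyl does, or has none. The two larger replacements cannot be told apart, a 1.9-fold lower number from compound 2 to compound 4 (0.29 log units; within the scatter), even though the ((chloromethyl)carbonyl)amino group has no ring. The step of an at least 2.0-fold lower number from compound 3 to compound 4 (0.30 log units; that floor lies within the scatter) rests on a limit and not a number, so it shows no firm change for (chloromethyl)carbonyl in place of hydrogen on the amide-type nitrogen: the limit of > 20000 nM in this assay, at which 1 of the 4 values shown sits.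

The compounds shown leave open whether any group on this carbonyl carbon can bring the number below that of compound 1, and whether the butoxy owes its place to its oxygen or to its chain, which an ethoxy, a hexyloxy or a plain pentyl chain would separate. They also leave open what the chlorine contributes, which a plain acetyl in place of the (chloromethyl)carbonyl would address.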